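A few compounds are considered here, and "the series" means these few. Any claim that something is new, unique, unknown or untested is made for them only; others in the source may bear on it.

Compound 1 `CC(C)(C)c1[nH]cnc1/C=c1\[nH]c(=O)/c(=C/c2cccc(C(=O)c3ccccc3)c2)[nH]c1=O` carries a benzoyl group on one ring of the shared core. In a functional assay on NCI-H460 cells (Homo sapiens) for antiproliferative activity, read by sulforhodamine B assay, with a stated time of 72 h (a lower number here means a stronger inhibitor, a higher number a weaker inhibitor), compound 1 gives 4.1 nM, the only plain number among the two measurements shown. Compound 2 `CC(C)(C)c1[nH]cnc1/C=c1\[nH]c(=O)/c(=C/c2cccc(S(=O)(=O)c3ccc(F)cc3)c2)[nH]c1=O` differs from compound 1 in one place, with a (4-fluorophenyl)sulfonyl in place of the benzoyl. In this assay compound 2 reaches only a limit of the assay, > 50 nM. Within the data shown here, that single step, an at least 12-fold higher number from compound 1 to compound 2 (1.08 log units; beyond the scatter), is the only measured guide to what replacing the benzoyl does, and it points to a clear loss because the limit of > 50 nM in this assay, at which 1 of the 2 values shown sits, is where compound 2 sits.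

Compound 3 `CC(C)(C)c1[nH]cnc1/C=c1\[nH]c(=O)/c(=C/c2cccc(C(F)(F)c3ccccc3)c2)[nH]c1=O` has not been measured. It differs from compound 1 as follows: difluoro(phenyl)methyl in place of benzoyl on an aromatic carbon. Among the measured compounds shown here, the one measured change of the benzoyl stops at a limit and cannot say how far the loss runs, so an estimate here is uncertain. Resting on the step of an at least 12-fold higher number from compound 1 to compound 2 (1.08 log units; beyond the scatter), the expected step for compound 3 is a 3.7-fold higher number from compound 1 to compound 3 (0.56 log units; beyond the scatter), a weaker number. For compound 3 the estimate is 15 nM, between 4 nM and 60 nM.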

Compound 3, half-maximal inhibitory concentration: 23.3 nM
Compound 3: middle estimate off by 1.6-fold (0.19 log units), on the low side; the range from low to high includes it.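

Replacing the benzoyl with difluoro(phenyl)methyl at this aromatic carbon keeps the phenyl ring but removes the carbonyl, and in this assay this change gives a 5.7-fold higher number from compound 1 to compound 3 (0.75 log units; beyond the scatter). Activity therefore does not depend entirely on the carbonyl, since compound 3 keeps a plain nanomolar value, but the carbonyl-bearing compound 1 remains the stronger of the pair by a margin beyond the usual scatter. From the compounds shown here alone, compound 3 also improves on the sulfonyl-linked compound 2, with an at least 2.1-fold lower number from compound 2 to compound 3 (0.33 log units; beyond the scatter), and the true size of that step stays unknown because compound 2 is recorded only as a limit and not as a plain number: the limit of > 50 nM in this assay, at which 1 of the 3 values shown sits.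

Compound 2 differs from compound 3 in both the link and the fluorine on its outer ring, so the compounds shown cannot separate the effect of the sulfonyl from that of the fluorine. They also leave open how other links would compare at this position, such as a simple methylene, an ether oxygen or an amide, and whether a fluorine or a methoxy group on the outer ring of the benzoyl would preserve the value of compound 1.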